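An Aryl Amide Replaces a Cyclopentyl Amide

A few compounds are considered here, and "the series" means these few. Any claim that something is new, unique, unknown or untested is made for them only; others in the source may bear on it.

In an assay on HEK293 cells for positive allosteric modulation of metabotropic glutamate receptor 5 (Homo sapiens), read by FLIPR, with a stated time of 1 h (on this read-out higher numbers stand for an effect only at larger amounts of compound and lower numbers for an effect already at smaller amounts), compound 3 `O=C(C1CCCC1)N1CCc2nc(C#Cc3ccccc3)sc2C1` gives 19 nM, the lowest of the two numbers measured here. Compound 2 `CCCCN1CCc2nc(C#Cc3ccccc3)sc2C1` gives 110 nM, and the gap is a 5.8-fold lower number from compound 2 to compound 3 (0.76 log units; beyond the scatter). Compound 1 `CCN1CCc2nc(C#Cc3ccccc3)sc2C1` gives only a limit of the assay, > 10000 nM. Compound 4 `N#Cc1cccc(C(=O)N2CCc3nc(C#Cc4ccccc4)sc3C2)c1` differs from compound 3 by 3-cyanophenyl in place of cyclopentyl on a carbonyl carbon. All measured steps change the group on the ring nitrogen: an at least 90-fold lower number from compound 1 to compound 2 (1.95 log units; beyond the scatter) and an at least 520-fold lower number from compound 1 to compound 3 (2.72 log units; beyond the scatter) were large, while a 5.8-fold lower number from compound 2 to compound 3 (0.76 log units; beyond the scatter) was modest. None of them compares two different groups on the carbonyl carbon, so the change from compound 3 to compound 4 is expected to stay within the scatter. Compound 4 is accordingly expected to show a 1.3-fold lower number from compound 3 to compound 4 (0.10 log units; within the scatter). Compound 4 is estimated at 15 nM, between 4 nM and 60 nM.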

Compound 4, half-maximal effective concentration: 71 nM
Compound 4: middle estimate off by 4.7-fold (0.68 log units), on the low side; the measured number lies above the stated range.
By their numbers in this assay, from the lowest: compound 3; then compounds 4 and 2 (each within the scatter of the next). At a limit, above all of these: compound 1.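

This step is the only one here that compares two groups on the carbonyl carbon, and 3-cyanophenyl in place of cyclopentyl gives a 3.7-fold higher number from compound 3 to compound 4 (0.57 log units; beyond the scatter) and so needs more compound for the same effect. The group on the carbonyl carbon therefore matters, and an aromatic ring carrying a nitrile keeps activity without matching the cyclopentyl amide. Nothing shown gives a measured reason for this step. Still open, from the compounds shown here alone, is how an unsubstituted phenyl or a cyclohexyl on the carbonyl carbon would compare, so the effects of the aromatic ring and the nitrile remain unseparated.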